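Aryl exchange from compound 3 to compound 4

A few compounds are considered here, and "the series" means these few. Any claim that something is new, unique, unknown or untested is made for them only; others in the source may bear on it.

The series shares one core and varies the aryl group: compound 1 `CCC1=C(O)c2c(oc(-c3ccc(CC)cc3)cc2=O)C(CC)(CC)C1=O`, compound 2 `CCC1=C(O)c2c(oc(-c3ccc(F)cc3)cc2=O)C(CC)(CC)C1=O` and compound 3 `CCC1=C(O)c2c(oc(-c3ccc(COC)cc3)cc2=O)C(CC)(CC)C1=O`. In a functional assay on KB cells (Homo sapiens) for antiproliferative activity, read by sulforhodamine B assay, with a stated time of 3 days (on this read-out lower numbers stand for an effect already at smaller amounts and higher numbers for an effect only at larger amounts of compound), compound 1 gives 21.9 uM and compound 2 gives 33 uM. Compound 3 reads > 52.4 uM, which is a limit and not a number; it stands at the limit of > 52.4 uM in this assay, at which 1 of the 3 values shown sits.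

Compound 4 `CCC1=C(O)c2c(oc(-c3ccccc3OC)cc2=O)C(CC)(CC)C1=O` carries 2-methoxyphenyl in place of 4-(methoxymethyl)phenyl on an aromatic carbon.

Three measured steps change the same aryl group. The first, a 1.5-fold higher number from compound 1 to compound 2 (0.18 log units; within the scatter), stays within the scatter. The second, an at least 1.5-fold higher number from compound 2 to compound 3 (0.20 log units; that floor lies within the scatter), has a floor within the scatter. The third, an at least 2.3-fold higher number from compound 1 to compound 3 (0.37 log units; beyond the scatter), is modest and beyond the scatter. Going by the values given here, no measured step covers a 2-methoxyphenyl group, so the expectation rests only on these sizes, and a large change is not expected.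

The step expected is an at least 1.7-fold lower number from compound 3 to compound 4 (0.24 log units; that floor lies within the scatter), small and toward a lower number.

For compound 4 the estimated value in this assay is 30 uM, with an expected range of 13 uM to 70 uM.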

Compound 4, concentration for half-maximal effect: 40.8 uM
Compound 4: middle estimate off by 1.4-fold (0.13 log units), on the low side; the measured number falls inside the stated range.
By their numbers in this assay, from the lowest: compounds 1, 2 and 4 (each within the scatter of the next). At a limit, above all of these: compound 3.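

In this assay compound 3 remains a limit and not a number: the limit of > 52.4 uM in this assay, at which 1 of the 4 values shown sits. Against 4-(methoxymethyl)phenyl, 2-methoxyphenyl gives an at least 1.2-fold lower number from compound 3 to compound 4 (0.10 log units; that floor lies within the scatter), so this exchange at the aromatic carbon next to the ring oxygen yields a measured number, but no real gain can be claimed from a floor of that size. Against the other aryl groups it gives a 1.2-fold higher number from compound 2 to compound 4 (0.09 log units; within the scatter) and a 1.9-fold higher number from compound 1 to compound 4 (0.27 log units; within the scatter), both within the scatter, so 2-methoxyphenyl cannot be told apart from 4-fluorophenyl or 4-ethylphenyl, and the only aryl step shown beyond the scatter remains the one between compound 1 and compound 3.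

As far as these compounds go, whether an aryl group carrying an amine or a carboxylic acid would move the number beyond the scatter in either direction stays open. From the compounds shown here alone, how far compound 3 actually lies from compound 4 also stays open.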